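A few compounds are considered here, and "the series" means these few. Any claim that something is new, unique, unknown or untested is made for them only; others in the source may bear on it.

In a functional assay on MCF7 cells (Homo sapiens) for antiproliferative activity (a higher number here means a weaker inhibitor, a lower number a stronger inhibitor), compound 1 `O=C(CCl)Nc1ccc(-c2nc3ccccc3s2)cc1` gives > 10 nM, which is a limit and not a number. Compound 2 `O=C(Nc1ccc(-c2nc3ccccc3s2)cc1)C(Cl)Cl` gives > 100 nM, which is also a limit, so it has no exact position on the scale. Within the data shown here, the only measured change is a step that the two limits leave unreadable from compound 1 to compound 2, and it offers no usable size. Compound 3 `O=C(Nc1ccc(-c2nc3ccccc3s2)cc1)c1ccccc1` differs from compound 2 as follows: phenyl in place of dichloromethyl on a carbonyl carbon. With no readable step as a guide, no direction can be firmly expected in this assay. The estimated change is a step that the limit leaves unreadable from compound 2 to compound 3. Compound 3 is expected near 300 nM, with an estimated range from 80 nM to 3000 nM.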

Compound 3, half-maximal inhibitory concentration: > 1000 nM
Compound 3: only a limit was reported; the forecaster's own chance of this, stated with the estimate: 60%; middle value at least 3.3-fold (0.52 log units) from the limit.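

Compound 3 is reported only as a limit, like compound 1 and compound 2, so no step among these compounds can be read. The compounds shown leave open how strongly each one actually acts in this assay.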